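A few compounds are considered here, and "the series" means these few. Any claim that something is new, unique, unknown or untested is made for them only; others in the source may bear on it.

Measured in a toxicity assay on Hepa-1c1c7 cells (Mus musculus) for inhibition; on this read-out higher numbers stand for weaker inhibition and lower numbers for stronger inhibition:
- compound 1 `CCCCCCCCCC(O)C#CC#CC(O)CCC`: 30000 nM
- compound 2 `CCCCC[C@@H](O)C#CC#CCO`: > 100000 nM, a limit
- compound 3 `CCCCCC(O)C#CC#CCO`: > 50000 nM, a limit

Going by the values given here, compound 1 holds the only actual number in this set, as the other two values are limits. Compound 4 `CCCCCCCCCC(O)C#CC#CC(O)CCCCCCCCC` differs from compound 1 by hexyl in place of hydrogen on a saturated chain carbon, four bonds along the chain from an oxygen on a saturated carbon and a triple-bonded carbon, which lengthens the chain by a hexyl group.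

Among the compounds with values here, the one measured step is a step that the two limits leave unreadable from compound 2 to compound 3. It concerns a drawn configuration, not a hexyl group, so it offers no size or direction to carry over. In this assay, a step beyond the scatter is therefore not expected, leaving compound 1 at 30000 nM as the only anchor. The expected outcome is no change at the digits printed from compound 1 to compound 4 (within the scatter). For compound 4 the estimated value is 30000 nM, with an expected range from 10000 nM to 100000 nM.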

Compound 4, half-maximal inhibitory concentration: 26000 nM
Compound 4: the middle estimate sits 1.2-fold (0.06 log units) above what was measured; the measured number falls inside the stated range.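

In this assay there is a 1.2-fold lower number from compound 1 to compound 4 (0.06 log units; within the scatter) with hexyl in place of hydrogen on a saturated chain carbon, four bonds along the chain from an oxygen on a saturated carbon and a triple-bonded carbon. Going by these compounds alone, this is the first readable step in the set, and it shows that this position takes a hexyl group with no change beyond the scatter. Nothing in the data shown bears on why the read-out holds.

The step between compound 2 and compound 3 cannot be read. The compounds shown leave open how an amine, a carboxylic acid or a longer chain would read at this position.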